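The source may report more compounds than this note shows. Statements on the series, on what has been measured and on what is new or still open speak of the compounds shown alone.

Measured so far in an assay on HEK293 cells for antagonist activity at transient receptor potential cation channel subfamily V member 2 (Rattus norvegicus), read by fluorescence and calcium flux, with a stated time of 5 min; a lower number here means a stronger inhibitor, a higher number a weaker inhibitor:

Compound 1, `CCCCCCCC/C=C\CCCCCCCCSC[C@H](N)C(=O)NCc1ccc(O)c(OC)c1`: 1900 nM
Compound 2, `CCCCCC[C@@H](O)C/C=C\CCCCCCCCSCCC(=O)NCc1ccc(O)c(OC)c1`: a limit, > 10000 nM
Compound 3, `CCCCCCCCCCCCCCCCSCCC(=O)NCc1ccc(O)c(OC)c1`: 3800 nM

Compound 3 gives the highest of the two numbers in this assay, with compound 1 two steps away in structure and, as the numbers show, only a small distance away in value. Compound 2 reaches only a limit of this assay, and that limit is also the line at which the limit of > 10000 nM in this assay, at which 1 of the 3 values shown sits, sits.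

Among the compounds with values here, the one step that is measured runs an at least 2.6-fold lower number from compound 2 to compound 3 (0.42 log units; beyond the scatter). It concerns the far end of the chain and not the position now in question.

Compound 4, `CCCCCCCCCCCCCCCCSC[C@H](N)C(=O)NCc1ccc(O)c(OC)c1`, is the next compound to be measured in this assay. It differs from compound 3 in one place: amino in place of hydrogen on a saturated chain carbon bound to a carbonyl carbon and a saturated chain carbon. Within the data shown here, no measured step bears directly on this change. Compound 1 carries the same amino group but on a different chain, so its value and that of compound 3 can only be set side by side, and they lie within the scatter of each other.

On that basis the step of a 1.5-fold lower number from compound 3 to compound 4 (0.18 log units; within the scatter) is expected to be small, and compound 4 is estimated at 2500 nM, between 1000 nM and 7000 nM.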

Compound 4, half-maximal inhibitory concentration: 1400 nM
Compound 4: the middle estimate sits 1.8-fold (0.25 log units) above what was measured; measured number inside the range.
By their numbers in this assay, from the lowest: compounds 4, 1 and 3 (each within the scatter of the next, the first and the last beyond it). At a limit, above all of these: compound 2.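

In this assay, within the data shown here, the amino group on a saturated chain carbon bound to a carbonyl carbon and a saturated chain carbon now has a measured step of its own, a 2.7-fold lower number from compound 3 to compound 4 (0.43 log units; beyond the scatter), which lies beyond the scatter, whereas the earlier compounds allowed only a side-by-side reading of two values on different chains. With the amino group in place, the change to octyl in place of dec-1-en-1-yl on a saturated chain carbon, eight bonds along the chain from a sulfur, gives a 1.4-fold lower number from compound 1 to compound 4 (0.13 log units; within the scatter), so the two chains cannot be told apart in this pair. Nothing measured here accounts for the effect of the amino group.

The compounds shown leave open how a methylamino group or a carboxylic acid would behave on the same carbon. They also leave open whether the amino group has a similar effect on a longer chain.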